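Replacing the benzyloxy group with a direct aryl bond

The compounds below may be only part of what the source reports. "The series", "measured", "known", "first", "only" and "open" are said of these compounds alone.

Compound 1 `CC(C)COc1cc(C(F)(F)F)ccc1CNC(=O)C(C)c1ccc(NS(C)(=O)=O)c(F)c1` gives 0.8 nM in an assay on CHO cells for antagonist activity at transient receptor potential cation channel subfamily V member 1 (Homo sapiens), read by FLIPR; on this read-out higher numbers stand for weaker inhibition and lower numbers for stronger inhibition. Compound 2 `CC(C)CCOc1cc(C(F)(F)F)ccc1CNC(=O)C(C)c1ccc(NS(C)(=O)=O)c(F)c1` gives 0.5 nM in this assay. Compound 3 `CC(C(=O)NCc1ccc(C(F)(F)F)cc1OCc1ccc(F)cc1)c1ccc(NS(C)(=O)=O)c(F)c1` gives 0.5 nM in this assay.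

On these numbers compound 3 and compound 2 share the lowest value, though no change at the digits printed from compound 2 to compound 3 (within the scatter) and a 1.6-fold lower number from compound 1 to compound 3 (0.20 log units; within the scatter). Compound 4 `CC(C(=O)NCc1ccc(C(F)(F)F)cc1-c1cccc(Cl)c1)c1ccc(NS(C)(=O)=O)c(F)c1` differs from compound 3 in one place: 3-chlorophenyl in place of (4-fluorobenzyl)oxy on an aromatic carbon. Within the data shown here, none of the measured steps covers such a change; each of them, a 1.6-fold lower number from compound 1 to compound 2 (0.20 log units; within the scatter) and no change at the digits printed from compound 2 to compound 3 (within the scatter), only swapped the group on the saturated chain carbon bound to the ring oxygen, and all stayed within the scatter. With the oxygen-linked group removed entirely, the expectation for compound 4 is a modestly higher number, a 6.0-fold higher number from compound 3 to compound 4 (0.78 log units; beyond the scatter), with wide uncertainty. Compound 4 is therefore estimated at 3 nM, between 0.5 nM and 20 nM.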

Compound 4, inhibition constant: 1 nM
Beside the measured number, compound 4's estimate is 3.0-fold (0.48 log units) above it, within the range that was stated.
By their numbers in this assay, from the lowest: compounds 2, 3, 1 and 4 (each within the scatter of the next).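

The earlier compounds shown here changed only the group on the chain carbon bound to the ring oxygen. Compound 4 shows that in this assay this aromatic carbon, meta to a trifluoromethyl group, also takes 3-chlorophenyl with no ring oxygen at all (a 2.0-fold higher number from compound 3 to compound 4 (0.30 log units; within the scatter); a 2.0-fold higher number from compound 2 to compound 4 (0.30 log units; within the scatter); a 1.3-fold higher number from compound 1 to compound 4 (0.10 log units; within the scatter)). All three steps lie within the scatter, and nothing at hand accounts for this tolerance.

Still open, going by these compounds, is whether the chlorine of 3-chlorophenyl matters to the number. On these data alone, it is also open whether an amine or a carboxylic acid on this aromatic carbon would keep the number in this range.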